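Benzyl substitution on the imide nitrogen of the core

The source may hold more compounds than are shown below. What is called first, only, known or untested is meant among the compounds shown, and "the series" means these compounds.

Measured compounds and values in an assay on isolated protein for inhibition of lysosomal alpha-glucosidase (Rattus norvegicus), read by colorimetric assay; a higher number here means a weaker inhibitor, a lower number a stronger inhibitor:
compound 1 `Cc1ccc(S(=O)(=O)Nc2ccc3c(c2)C(=O)N(Cc2ccc(Cl)cc2)C3=O)cc1`: 188000 nM
compound 2 `Cc1ccc(S(=O)(=O)Nc2ccc3c(c2)C(=O)N(CCNc2ccc(O)c(O)c2)C3=O)cc1`: 28800 nM
compound 3 `Cc1ccc(S(=O)(=O)Nc2ccc3c(c2)C(=O)N(C)C3=O)cc1`: > 200000 nM

Compound 3 reports only a limit of the assay, not a number. That limit is where compound 3 stands; it sits at the limit of > 200000 nM in this assay, at which 1 of the 3 values shown sits. Compound 1 sits close to that limit: the step of an at least 1.0-fold higher number from compound 1 to compound 3 (0.02 log units; that floor lies within the scatter) is within the scatter at its floor. Compound 2 is the only one clearly away from the limit, by an at least 6.9-fold higher number from compound 2 to compound 3 (0.84 log units; beyond the scatter), and the step of a 6.5-fold lower number from compound 1 to compound 2 (0.81 log units; beyond the scatter) shows the same gap from the other side.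

Compound 4 `Cc1ccc(S(=O)(=O)Nc2ccc3c(c2)C(=O)N(Cc2ccccc2F)C3=O)cc1` has not been measured in this assay. It differs from compound 3 by 2-fluorophenyl in place of hydrogen on a saturated chain carbon bound to an amide-type nitrogen in a ring. Among the measured compounds shown here, the nearest measured step is the one from compound 1 to compound 3, where the 4-chlorophenyl on the same carbon made no difference beyond the scatter. A 2-fluorophenyl at that position is therefore expected to leave the number near the limit, with an at least 1.0-fold lower number from compound 3 to compound 4 (0.02 log units; that floor lies within the scatter) taken as no step beyond the scatter. The estimate for compound 4 is 190000 nM, within 80000 nM to 450000 nM, and a limit-only reading is a real possibility.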

Compound 4, half-maximal inhibitory concentration: 195000 nM
Beside the measured number, compound 4's estimate is 1.0-fold (0.01 log units) below it; the range from low to high includes it.
By their numbers in this assay, from the lowest: compound 2; then compounds 1 and 4 (each within the scatter of the next). At a limit, above all of these: compound 3.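

In this assay, 2-fluorophenyl and 4-chlorophenyl on the saturated chain carbon bound to the amide-type nitrogen in a ring are not told apart, with a 1.0-fold higher number from compound 1 to compound 4 (0.02 log units; within the scatter). The change from methyl to 2-fluorobenzyl reads an at least 1.0-fold lower number from compound 3 to compound 4 (0.01 log units; that floor lies within the scatter), but this is only a floor set by the limit reported for compound 3, so it gives no size for the change. The group carried by compound 2 stays apart from the 2-fluorobenzyl group, with a 6.8-fold higher number from compound 2 to compound 4 (0.83 log units; beyond the scatter), so the second halogen-bearing benzyl group in the set does not close the gap seen earlier with compound 1.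

The compounds shown leave open whether that gap belongs to the hydroxyl groups on the ring of compound 2, to its chain nitrogen or to its longer chain, since these differ together from the benzyl groups. A 2-phenylaminoethyl group without hydroxyl groups, or a benzyl group carrying an amine or a carboxylic acid, would help separate these features at the same position on the shared core.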